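The compounds below may be only part of what the source reports. "The series", "measured", "known", "first", "only" and "open" are said of these compounds alone.

Of the compounds shown here, three have been tested in a functional assay on SMMC-7721 cells (Homo sapiens) for inhibition, read by MTT assay, with a stated time of 72 h, tested at 10 uM; a higher number here means a stronger effect of the compound at the concentration tested, a lower number a weaker effect. Compound 2 `Cc1cccc(COc2ccc(/C=C/C(/C=C/c3ccccn3)=N/Oc3ncnc4cccc(C)c34)cc2)c1` gives 97%, the highest of the three numbers. Compound 1 `Clc1ccc(COc2ccccc2/C=C/C(/C=C/c2ccccn2)=N/Oc2ncnc3cc(Cl)ccc23)c(Cl)c1` comes nearest, giving 91.8%, a gap that lies within the usual scatter, so the two cannot be placed in any order. Compound 3 `Clc1ccc(COc2ccc(/C=C/C(/C=C/c3ccccn3)=N/Oc3ncnc4cc(Cl)ccc34)cc2)c(Cl)c1` lies furthest away, with 23.6%, a gap well beyond the scatter.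

The unmeasured compound 4 `Cc1cccc(COc2ccc(/C=C/C(/C=C/c3ccccn3)=N/Oc3ncnc4ccccc34)cc2)c1` differs from compound 2 in one place: hydrogen in place of methyl on an aromatic carbon. Among the measured compounds shown here, no pair of measured compounds differs by this change alone, so nothing measured shows directly what this change does. Since the three measured values show that large shifts are possible, but the loss of one methyl is a small change, the expectation for compound 4 is a modest downward step, a number 9 percentage points lower from compound 2 to compound 4 (within the scatter), not clearly beyond the scatter. Compound 4 is therefore estimated to give 88%, within a range from 65% to 99%.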

Compound 4, a percentage reported as inhibition, at one concentration (the size of the read-out at that concentration, not a potency): 97.5%
Beside the measured number, compound 4's estimate is 9.5 percentage points below it; measured number inside the range.
By their numbers in this assay, from the lowest: compound 3; then compounds 1, 2 and 4 (each within the scatter of the next).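

In this assay, among the compounds shown here, the quinazolin-4-yl group of compound 4 replaces the 5-methylquinazolin-4-yl group of compound 2 (a number 0.5 percentage points higher from compound 2 to compound 4 (within the scatter)), the first direct reading of this change. The methyl on this aromatic carbon, ortho to a fused ring, is therefore not needed to keep the read-out at this one concentration, at least in this pair. Nothing given here explains why the two compounds read alike.

Since the read-out comes from a single concentration, the compounds shown leave open whether the pair would still match at lower concentrations. They also leave open whether a methoxy group, an amine or a carboxylic acid on this same carbon would be accepted as readily as hydrogen and methyl.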